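The source may report more compounds than this note shows. Statements on the series, on what has been measured and on what is new or still open speak of the compounds shown alone.

In a functional assay on A549 cells (Homo sapiens) for cytotoxicity, read by MTT assay, with a stated time of 48 h (a lower number here means a stronger inhibitor, a higher number a weaker inhibitor), compound 1 `C=C1CCC[C@]2(C)CCC(C=O)=CC[C@@]12C` gives 145000 nM and compound 2 `CC1(C)CCCC2=CC=C(C=O)CC[C@]21C` gives 138000 nM. Compound 3 `C=C1CCC[C@]2(C)CCC(c3cn(-c4ccc(C(C)=O)cc4)nn3)=CC[C@@]12C` gives 46400 nM, the lowest of the three numbers, and its gaps to compound 1 and compound 2 both lie beyond the scatter. Compound 4 `C=C1CCC[C@]2(C)CCC(c3cn(-c4ccccc4C(C)=O)nn3)=CC[C@@]12C` has the same atoms as compound 3, joined differently, with 2-acetylphenyl in place of 4-acetylphenyl on an aromatic nitrogen. Among the compounds with values here, no measured pair differs in one place, so the size of this exchange in this assay has no direct precedent. A small step towards a higher number, within the scatter, is expected, and the estimated change is a 1.3-fold higher number from compound 3 to compound 4 (0.11 log units; within the scatter). For compound 4 the expected value is 60000 nM, with an estimated range of 28000 nM to 130000 nM.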

Compound 4, half-maximal inhibitory concentration: 37700 nM
Compound 4: middle estimate off by 1.6-fold (0.20 log units), on the high side, and the stated range covers the measured number.
By their numbers in this assay, from the lowest: compounds 4 and 3 (each within the scatter of the next); then compounds 2 and 1 (each within the scatter of the next).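

In this assay, putting 2-acetylphenyl in place of 4-acetylphenyl on the aromatic nitrogen gives a 1.2-fold lower number from compound 3 to compound 4 (0.09 log units; within the scatter) and so stays within the scatter. Within the data shown here, this is the first pair here that differs in one place, and it shows that on this phenyl ring the two acetyl placings cannot be told apart by this read-out. Nothing measured bears on why the two compounds read alike. Still open, from the compounds shown here alone, is whether an amine or a carboxylic acid in place of the acetyl would shift the number, and whether plain phenyl would read the same.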